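Pendant aryl variation on a shared tetrahydroisoquinoline-benzofuran series

This account rests on a few compounds, and the source may have more. Where it says the series, first, only, none or still open, it means among the compounds named here.

Going by the values given here, compound 1 `COc1cc2c(cc1OC)CN(Cc1ccc(OC)c3oc(-c4ccccc4C(F)(F)F)cc13)CC2` is the only member of this set with a number in an in vitro assay on COS-7 cells for displacement of a labelled ligand from Alpha-2B adrenergic receptor (Homo sapiens) (on this read-out higher numbers stand for weaker inhibition and lower numbers for stronger inhibition), where compound 1 gives 949 nM. Compound 2 `COc1cc2c(cc1OC)CN(Cc1ccc(OC)c3oc(-c4cccc(C#N)c4)cc13)CC2`, which carries a cyano group on the six-membered aromatic ring of carbon only, is recorded in this assay as "not determined" (no result reported), so compound 2 stands without a number. Among the compounds with values here, compound 3 `CCCNC(=O)c1cccc(-c2cc3c(CN4CCc5cc(OC)c(OC)cc5C4)ccc(OC)c3o2)c1` likewise is recorded in this assay as "not determined" (no result reported), and no step between measured compounds can be drawn anywhere in the set.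

Compound 4 `COc1cc2c(cc1OC)CN(Cc1ccc(OC)c3oc(-c4cccc(C(=O)NCCN(C)C)c4)cc13)CC2` differs from compound 2 by (2-(dimethylamino)ethyl)carbamoyl in place of cyano on an aromatic carbon. Within the data shown here, with compound 2 unmeasured, nothing in the data fixes the size or direction of the change in this assay; a step beyond the usual scatter cannot be predicted either way, and the only anchor is the value of compound 1 in the same assay.

Taking compound 1 as the reference point with 949 nM, compound 4 is expected to fall near 700 nM, with a plausible range from 120 nM to 4000 nM.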

Compound 4, inhibition constant: 584 nM
For compound 4 the middle estimate is 1.2-fold (0.08 log units) above the measured one; low and high end bracket the measured number.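

No new step can be read from the result for compound 4, either to compound 2 or to compound 1. The compounds shown leave open how (2-(dimethylamino)ethyl)carbamoyl compares with cyano on the shared core in this assay. No supporting evidence bears on this result.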